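This account rests on a few compounds, and the source may have more. Where it says the series, first, only, none or still open, it means among the compounds named here.

Measured compounds:
- compound 1, `CCCCC[Se]c1nc(NCc2ccc(SC)cc2)c2ccccc2n1`: 35000 nM
- compound 2, `CCCCC[Se]c1nc(NCc2ccccc2)c2ccccc2n1`: 34500 nM

Both numbers come from a functional assay on CCRF-CEM cells (Homo sapiens) for cytotoxicity, read by MTT assay, with a stated time of 72 h; a higher number here means a weaker inhibitor of growth, a lower number a stronger inhibitor of growth. Among the compounds with values here, compound 1 and compound 2 sit together: the step of a 1.0-fold lower number from compound 1 to compound 2 (0.01 log units; within the scatter), hydrogen in place of methylsulfanyl on an aromatic carbon, does not separate them beyond the scatter, so compound 1 stands level with the only other measured compound.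

Compound 3, `CSc1ccc(CNc2nc([Se]C)nc3ccccc23)cc1`, is not yet measured. It differs from compound 1 by hydrogen in place of butyl on a saturated chain carbon bound to a selenium atom; the same change, cut one bond further out, reads pentyl to methyl on the selenium-bearing chain. Within the data shown here, no measured step touches this chain; the single known step concerns the aromatic substituent and is within the scatter, so nothing here points in either direction. The working expectation is therefore a step of no change at the digits printed from compound 1 to compound 3 (within the scatter) of no size beyond the scatter, with a wide range to reflect the lack of precedent. Compound 3 is estimated at 35000 nM, between 10000 nM and 120000 nM.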

Compound 3, concentration for 50% growth inhibition: 48700 nM
Compound 3: the middle estimate sits 1.4-fold (0.14 log units) below what was measured; measured number inside the range.
By their numbers in this assay, from the lowest: compounds 2, 1 and 3 (each within the scatter of the next).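

Working notes on the selenium-bearing chain: in this assay the change from pentyl to methyl gives a 1.4-fold higher number from compound 1 to compound 3 (0.14 log units; within the scatter) and is the first measured step at this position. Hydrogen in place of butyl, on a saturated chain carbon bound to a selenium atom, takes away 4 heavy atoms without separating the two compounds beyond the scatter, so these two chain lengths are not told apart in this read-out. Nothing available bears on why these two compounds read alike.

From the compounds shown here alone, only the pentyl and methyl ends of this chain are covered, so it remains open whether a longer chain such as octyl, or a chain ending in an amine or a carboxylic acid, would read differently. Also open, going by these compounds, is whether a sulfur atom in place of selenium would leave the number unmoved.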